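This account rests on a few compounds, and the source may have more. Where it says the series, first, only, none or still open, it means among the compounds named here.

Measured so far:
compound 1 `NC1CCC(Nc2nc(NCc3ccc(Br)cc3)c3ncn(C4CCCC4)c3n2)CC1` gives 790 nM
compound 2 `NC1CCC(Nc2nc(NCc3ccc(-c4ccsc4)cc3)c3ncn(C4CCCC4)c3n2)CC1` gives 315 nM

Compound 2 holds the lower of these two numbers in a functional assay on HCT-116 cells (Homo sapiens) for inhibition, with a stated time of 72 h (a higher number here means a weaker inhibitor, a lower number a stronger inhibitor), and is the starting point here. Compound 3 `NC1CCC(Nc2nc(NCc3ccc(-n4cccn4)cc3)c3ncn(C4CCCC4)c3n2)CC1` differs from it by 1H-pyrazol-1-yl in place of thiophen-3-yl on an aromatic carbon with 1H-pyrazol-1-yl in place of thiophen-3-yl on an aromatic carbon, para to a large group. Going by the values given here, the only measured step at this place is a 2.5-fold lower number from compound 1 to compound 2 (0.40 log units; beyond the scatter) and it is modest, with thiophen-3-yl in place of bromo. Among the compounds with values here, no measured step covers the exchange of these two five-membered aromatic rings, so nothing beyond the scatter is expected. The expected change is a 1.3-fold higher number from compound 2 to compound 3 (0.10 log units; within the scatter) and leans slightly towards a higher number. For compound 3 the estimate is 400 nM with an expected span of 180 nM to 900 nM as its range.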

Compound 3, half-maximal inhibitory concentration: 320 nM
Compound 3: middle estimate off by 1.3-fold (0.10 log units), on the high side; the measured number falls inside the stated range.
By their numbers in this assay, from the lowest: compounds 2 and 3 (each within the scatter of the next); then compound 1.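

In this assay the exchange of thiophen-3-yl for 1H-pyrazol-1-yl gives a 1.0-fold higher number from compound 2 to compound 3 (0.01 log units; within the scatter) and so shows that, on this aromatic carbon, a five-membered aromatic ring with 2 hetero atoms and one with 1 hetero atom cannot be told apart. Replacing bromo with 1H-pyrazol-1-yl gives a 2.5-fold lower number from compound 1 to compound 3 (0.39 log units; beyond the scatter) and thus matches the printed size of a 2.5-fold lower number from compound 1 to compound 2 (0.40 log units; beyond the scatter) with a second five-membered aromatic ring. No measurement at hand explains this result.

From the compounds shown here alone, whether an amine or a carboxylic acid on this aromatic carbon would give a similar number remains open. So does the outcome with a six-membered ring such as pyridine.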